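Pyridin-2-yl on the Amide Nitrogen: From Compound 2 to Compound 4

The source may hold more compounds than are shown below. What is called first, only, known or untested is meant among the compounds shown, and "the series" means these compounds.

Three compounds of the series have been measured in an assay on HEK293 cells for agonist activity at transient receptor potential cation channel subfamily M member 8 (Homo sapiens), read by fluorescence and calcium flux, with a stated time of 15 min; on this read-out lower numbers stand for an effect already at smaller amounts and higher numbers for an effect only at larger amounts of compound:
compound 1, `CCN(Cc1ccoc1)C(=O)COc1ccc(C)cc1`, gives 136 nM;
compound 2, `Cc1ccc(OCC(=O)N(Cc2cccs2)CC(C)C)cc1`, gives 900 nM;
compound 3, `CCN(Cc1ccccn1)C(=O)COc1ccc(C)cc1`, gives 16000 nM.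

Compound 2 stands second highest of the three numbers; compound 1 sits closest to it with a lower value, and compound 3 lies furthest, with a higher value. The unmeasured compound 4, `Cc1ccc(OCC(=O)N(Cc2cccs2)c2ccccn2)cc1`, differs from compound 2 in one place: pyridin-2-yl in place of isobutyl on an amide-type nitrogen.

Within the data shown here, only one measured step bears on this change, and only loosely, since it puts pyridin-2-yl onto a saturated chain carbon rather than onto the amide-type nitrogen itself: a 120-fold higher number from compound 1 to compound 3 (2.07 log units; beyond the scatter). That step was large and went toward higher numbers. Among the measured compounds shown here, with no step that introduces pyridin-2-yl at the amide-type nitrogen, the expectation for compound 4 can only lean on that single direction, and it is expected that compound 4 moves to a clearly higher number, a 10-fold higher number from compound 2 to compound 4 (1.00 log units; beyond the scatter). The estimated value for compound 4 in this assay is therefore 9000 nM, with a range from 2000 nM to 50000 nM.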

Compound 4, half-maximal effective concentration: 200 nM
Estimate against measurement, compound 4: 45-fold (1.65 log units) above; the measured number lies below the stated range.
By their numbers in this assay, from the lowest: compounds 1 and 4 (each within the scatter of the next); then compound 2; then compound 3.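

The step of a 4.5-fold lower number from compound 2 to compound 4 (0.65 log units; beyond the scatter) in this assay shows that the amide-type nitrogen can carry a six-membered aromatic ring in place of isobutyl and still give a lower number. Until now, pyridin-2-yl had appeared only on a saturated chain carbon, in the step of a 120-fold higher number from compound 1 to compound 3 (2.07 log units; beyond the scatter), and the direction of that step does not carry over to the amide-type nitrogen. Nothing measured here explains why the same group goes with opposite directions at these two places.

The compounds shown leave open whether the lower number belongs to pyridin-2-yl itself or would also come with a phenyl or pyridin-3-yl group on this nitrogen. They also leave open how pyridin-2-yl on the amide-type nitrogen would fare with the furan-3-yl group of compound 1 on the saturated chain carbon.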